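The source may report more compounds than this note shows. Statements on the series, on what has been measured and on what is new or still open speak of the compounds shown alone.

Measured compounds in an in vitro functional assay on HEK ts201 cells for antagonist activity at Neuronal acetylcholine receptor; alpha4/beta2 (Homo sapiens), read by fluorescence and calcium flux; on this read-out higher numbers stand for weaker inhibition and lower numbers for stronger inhibition:
- compound 1, `O=C(OCC1CCCN(CCCc2ccccc2)C1)c1ccccc1-c1ccccc1`: 13500 nM; 13500 nM (2 entries)
- compound 2, `O=C(OCC1CCCN(CCCc2ccccc2)C1)c1ccccc1N1C(=O)CC(CCc2ccccc2)C1=O`: 5130 nM
- compound 3, `CC1CC(=O)N(c2ccccc2C(=O)OCC2CCCN(CCCCCOc3ccc(Cl)c(Cl)c3)C2)C1=O`: 17400 nM

Compound 3 holds the highest of the two single numbers in this assay; its nearest neighbour, compound 2, sits lower by an amount beyond the scatter. Compound 1 carries two entries rather than a single number, and its values and that of compound 3 lie close enough that no order between them can be read from this assay. The whole set remains in the weak range.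

Compound 4, `CC1CC(=O)N(c2ccccc2C(=O)OCC2CCCN(CCCCCOc3ccccc3)C2)C1=O`, has not been measured. It differs from compound 3 in one place: phenyl in place of 3,4-dichlorophenyl on an oxygen on a saturated carbon. Within the data shown here, no pair of measured compounds shows this difference, so there is no step to lean on; the pair of compounds 2 and 3 changes several parts at once and tells nothing about the aryl ether alone.

With nothing in the series to anchor the change, the expected step from compound 3 to compound 4 is a 1.4-fold higher number from compound 3 to compound 4 (0.16 log units; within the scatter), modest and toward a higher number, though a result within the scatter would not surprise. Compound 4 is therefore estimated at 25000 nM in this assay, with a range from 8000 nM to 80000 nM.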

Compound 4, half-maximal inhibitory concentration: 17000 nM
Compound 4: middle estimate off by 1.5-fold (0.17 log units), on the high side; measured number inside the range.
By their numbers in this assay, from the lowest: compound 2; then compounds 4 and 3 (each within the scatter of the next).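

In this assay, among these compounds, phenyl in place of 3,4-dichlorophenyl on an oxygen on a saturated carbon gives a 1.0-fold lower number from compound 3 to compound 4 (0.01 log units; within the scatter), the first step that isolates a single place. At this position, on this core and in this weak range, the two chlorine atoms make no readable difference: the phenoxy and 3,4-dichlorophenoxy ends cannot be told apart, so the aryl ether can be carried without its halogens with no visible cost on this read-out. No independent evidence bears on this result.

The compounds shown leave open whether a single chlorine, a methoxy group, a carboxylic acid or a pyridine ring at this place would read apart from phenyl, and whether a shorter or longer chain carrying the phenoxy group would do so. Among the compounds shown here, this pair also cannot say whether the same exchange would read the same way on a different acyl part of the ester, such as the one in compound 1 or compound 2.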